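Swapping a methyl for selenocyanate on the amide side chain

A few compounds are considered here, and "the series" means these few. Any claim that something is new, unique, unknown or untested is made for them only; others in the source may bear on it.

Measured compounds:
compound 1 `C#CC(=O)N(Cc1ccc(OC)c(O)c1)c1cc(OC)c(OC)c(OC)c1` gives 170 nM
compound 2 `COc1ccc(N(Cc2cc(OC)c(OC)c(OC)c2)C(=O)CCl)cc1O` gives 24500 nM
compound 3 `CCC(=O)N(Cc1ccc(OC)c(O)c1)c1cc(OC)c(OC)c(OC)c1` gives 50 nM

In a functional assay on MGC-803 cells (Homo sapiens) for inhibition, read by MTT assay, with a stated time of 48 h (a lower number here means a stronger inhibitor, a higher number a weaker inhibitor), compound 3 stands lowest of the three numbers, with compound 1 the nearest and compound 2 far above. Compound 4 `COc1ccc(CN(C(=O)C[Se]C#N)c2cc(OC)c(OC)c(OC)c2)cc1O` differs from compound 3 by a group of 3 heavy atoms (1 carbon, 1 nitrogen, 1 selenium; no ring) in place of one carbon atom, on a saturated chain carbon bound to a carbonyl carbon. Among the compounds with values here, only one measured step touches the same region: a 3.4-fold lower number from compound 1 to compound 3 (0.53 log units; beyond the scatter), a modest change at the carbonyl carbon. Compound 2, which also carries a substituted chain on the carbonyl but differs from compound 3 in a second place, shows a much higher number, so its two values give only a loose hint. A weakening step is therefore expected, of size a 6.0-fold higher number from compound 3 to compound 4 (0.78 log units; beyond the scatter), and compound 4 is estimated at 300 nM, within 60 nM to 1500 nM.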

Compound 4, half-maximal inhibitory concentration: 270 nM
The estimate for compound 4 lay 1.1-fold (0.05 log units) above the measured number; low and high end bracket the measured number.
By their numbers in this assay, from the lowest: compound 3; then compounds 1 and 4 (each within the scatter of the next); then compound 2.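

Putting the selenocyanate group on this saturated chain carbon in place of the methyl costs activity, a 5.4-fold higher number from compound 3 to compound 4 (0.73 log units; beyond the scatter), so the larger group does not match the plain methyl of compound 3. The comparison with the ethynyl compound, a 1.6-fold higher number from compound 1 to compound 4 (0.20 log units; within the scatter), separates neither compound from the other, so the two stand level. Nothing measured here gives a reason for the loss.

Going by these compounds, whether an amine or a longer chain at this carbon would do better stays open. So does the part selenium plays, which a thiocyanate, with sulfur in its place, would test.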